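The source may hold more compounds than are shown below. What is called first, only, known or untested is meant among the compounds shown, and "the series" means these compounds.

Compound 1 `O=C1N=C(C2C(=O)c3ccccc3C2=O)CC(c2ccccc2[N+](=O)[O-])N1` gives 35% in a functional assay on the whole organism for inhibition, with Mus musculus as the target, in the writhing test, with a stated time of 15 min, at a dose of 10 mg/kg; on this read-out lower numbers stand for less inhibition and higher numbers for more inhibition at the one dose given (going by the name of the read-out).
Compound 2 `O=C1N=C(C2C(=O)c3ccccc3C2=O)CC(c2ccc([N+](=O)[O-])cc2)N1` gives 38% in this assay.

Among the compounds with values here, on these two numbers compound 2 stands highest, and the one measured step, a number 3 percentage points higher from compound 1 to compound 2 (within the scatter), lies within the scatter. Compound 3 `O=C1N=C(C2C(=O)c3ccccc3C2=O)CC(c2ccc(Cl)cc2)N1` differs from compound 2 by chloro in place of nitro on an aromatic carbon. Within the data shown here, that measured step swaps 4-nitrophenyl for 2-nitrophenyl and says nothing about chloro in place of nitro, so no measured step bears on this change. The expected step of a number 2 percentage points lower from compound 2 to compound 3 (within the scatter) from compound 2 to compound 3 is therefore none beyond the scatter. Compound 3 is estimated at 36%, between 20% and 52%.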

Compound 3, a percentage reported as inhibition, in the whole organism at one dose (the size of the read-out at that dose, not a potency): 44%
For compound 3 the middle estimate is 8 percentage points below the measured one; the measured number falls inside the stated range.
By their numbers in this assay, from the lowest: compounds 1, 2 and 3 (each within the scatter of the next).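

In this assay, chloro in place of nitro gives a number 6 percentage points higher from compound 2 to compound 3 (within the scatter), and 4-chlorophenyl in place of 2-nitrophenyl gives a number 9 percentage points higher from compound 1 to compound 3 (within the scatter). Within the data shown here, the earlier compounds carried only nitro, so this is the first sign that the nitro group is not needed for a reading of this size: a single chlorine atom in its place leaves the number within the scatter. Nothing at hand explains this result. Still open, as far as these compounds go, is whether an amine, a carboxylic acid or a methoxy group in the same place would give a similar reading.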